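Methoxy for methylamino on the furan-bearing core

This account rests on a few compounds, and the source may have more. Where it says the series, first, only, none or still open, it means among the compounds named here.

Compound 2 `CNc1ncnc2c1c(-c1ccccc1)cn2[C@@H]1O[C@H](CO)[C@@H](O)[C@H]1O` and compound 1 `COc1ncnc2c1c(-c1ccccc1)cn2[C@@H]1O[C@H](CO)[C@@H](O)[C@H]1O` share the phenyl-bearing core. In a functional assay on K562 cells (Homo sapiens), read by MTT assay, with a stated time of 72 h (a higher number here means a weaker inhibitor, a lower number a stronger inhibitor), compound 2 gives only a limit, > 20000 nM. Compound 1 also gives only a limit in this assay, > 20000 nM. The change between them is methoxy in place of methylamino on an aromatic carbon, and the step is a step that the two limits leave unreadable from compound 2 to compound 1 because both values sit at the limit of > 20000 nM in this assay, at which 2 of the 3 values shown sit.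

Compound 3 `CNc1ncnc2c1c(-c1ccco1)cn2[C@@H]1O[C@H](CO)[C@@H](O)[C@H]1O` differs from compound 2 in its core by furan-2-yl in place of phenyl on an aromatic carbon; in this assay compound 3 gives 15100 nM, the step being an at least 1.3-fold lower number from compound 2 to compound 3 (0.12 log units; that floor lies within the scatter).

Compound 4 `COc1ncnc2c1c(-c1ccco1)cn2[C@@H]1O[C@H](CO)[C@@H](O)[C@H]1O` carries the same change as compound 1, (methoxy in place of methylamino on an aromatic carbon), on the core of compound 3. Since a step that the two limits leave unreadable from compound 2 to compound 1 is unreadable, only a small step, a 1.2-fold higher number from compound 3 to compound 4 (0.08 log units; within the scatter), is expected. Compound 4 is therefore estimated at 18000 nM, between 8000 nM and 40000 nM, with a limit rather than a number quite possible.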

Compound 4, half-maximal inhibitory concentration: 380 nM
Estimate against measurement, compound 4: 47-fold (1.68 log units) above; measured number outside the range, below it.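

In this assay, methoxy in place of methylamino on the furan-bearing core gives a 40-fold lower number from compound 3 to compound 4 (1.60 log units; beyond the scatter), and furan-2-yl in place of phenyl on the methoxy-bearing core gives an at least 52-fold lower number from compound 1 to compound 4 (1.72 log units; beyond the scatter). The methoxy change cannot be read on the phenyl-bearing core, so these compounds do not show whether its large step carries over from one core to the other, with compound 1 and compound 2 both at a limit: the limit of > 20000 nM in this assay, at which 2 of the 4 values shown sit. The furan-2-yl change is large on one core but is not shown to depend on the core: the same change on two cores in this assay, an at least 1.3-fold lower number (0.12 log units; that floor lies within the scatter) from compound 2 to compound 3 and an at least 52-fold lower number (1.72 log units; beyond the scatter) from compound 1 to compound 4; the limit leaves it open whether they differ.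

Open, on these data alone, is whether the large step is tied to the pairing of methoxy with furan-2-yl. Also open, as far as these compounds go, is whether ethoxy or dimethylamino in the same place on the furan-bearing core would give a comparable number.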